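Aryl replacement at the biaryl terminus of a cytotoxicity series

A few compounds are considered here, and "the series" means these few. Any claim that something is new, unique, unknown or untested is made for them only; others in the source may bear on it.

compound 1 `CCOC(=O)CCCCCOc1cccc(CN(C(=O)c2ccc(-c3cccnc3)cc2)C(C)C)c1` — in an ADME assay on BJ cells (Homo sapiens) for cytotoxicity, read by CellTiter-Glo and resazurin assay, with a stated time of 72 h (a higher number here means that more compound is needed for the effect, a lower number that less compound is needed), compound 1 gives > 26000 nM, a limit of the assay.
compound 2 `CCOC(=O)CCCCCOc1cccc(CN(C(=O)c2ccc(-c3cnc(OC)nc3OC)cc2)C(C)C)c1` — in this assay compound 2 gives > 26000 nM, a limit of the assay.

Compound 2 therefore stands at the limit of this assay, and nothing more precise is shown for it; the one further value shown is likewise a limit. The step that the two limits leave unreadable from compound 1 to compound 2 from one heteroaryl to another cannot be read, because both values sit at the limit of > 26000 nM in this assay, at which 2 of the 2 values shown sit.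

Compound 3 `CCOC(=O)CCCCCOc1cccc(CN(C(=O)c2ccc(-c3cccc(C(C)=O)c3)cc2)C(C)C)c1` differs from compound 2 by 3-acetylphenyl in place of 2,4-dimethoxypyrimidin-5-yl on an aromatic carbon. Among the measured compounds shown here, the only measured step bears on it solely in that a change of the terminal aryl did not move the value off the limit. No readable step size is available, so no shift beyond the scatter can be anticipated in this assay, in either direction. Compound 3 is expected to remain at the limit, with an estimate of 40000 nM and a range from 15000 nM to 100000 nM. The expected step is a step that the limit leaves unreadable from compound 2 to compound 3.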

Compound 3, half-maximal effective concentration: > 26000 nM
Compound 3: only a limit was reported; the forecaster's own chance of this, stated with the estimate: 80%; the middle value is on the limit's open side.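

No step among compound 1, compound 2 and compound 3 can be read in this assay, as all three values are limits: the limit of > 26000 nM in this assay, at which 3 of the 3 values shown sit.

The compounds shown leave open how far beyond the limit each lies, and whether any terminal aryl on the shared core would give a measurable value in this assay.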